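Compound 3: replacing the sugar on the triazole-linked series

This account rests on a few compounds, and the source may have more. Where it says the series, first, only, none or still open, it means among the compounds named here.

Compound 1 `O=C1c2c[n+]([O-])c3ccccc3c2C(=O)c2c1c1ccccc1n2Cc1cn([C@@H]2C[C@H](O)[C@@H](CO)O2)nn1` gives 820 nM as its measured value
Compound 2 `O=C1c2c[n+]([O-])c3ccccc3c2C(=O)c2c1c1ccccc1n2CCCCN1CCNCC1` gives 760 nM as its measured value

Going by the values given here, both values come from a toxicity assay on HEK-293T cells (Homo sapiens) for cytotoxicity, read by MTT assay, with a stated time of 72 h (a higher number here means a weaker inhibitor, a lower number a stronger inhibitor), and are the only numbers so far. Compound 1 holds the higher of the two numbers, but the gap to compound 2 lies within the scatter, so the pair carries no order.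

Compound 3 `CC1(C)OC[C@H](Cn2cc(Cn3c4c(c5ccccc53)C(=O)c3c[n+]([O-])c5ccccc5c3C4=O)nn2)O1` is still to be measured. It keeps the core of compound 1 and has (2,2-dimethyl-1,3-dioxolan-4-yl)methyl in place of 4-hydroxy-5-(hydroxymethyl)oxolan-2-yl on an aromatic nitrogen of a five-membered aromatic ring with 3 nitrogen. Among the compounds with values here, no measured pair shows this change or any other single change, so the size of the step is poorly constrained. Within the data shown here, the only guide is that compound 2 at 760 nM lies within the scatter of compound 1, despite a different group on the shared core. In this assay no step beyond the scatter is expected, and no direction is favoured. The estimated step of a 1.1-fold lower number from compound 1 to compound 3 (0.04 log units; within the scatter) is accordingly small. Compound 3 is expected at 750 nM with an estimated range of 300 nM to 1900 nM for now.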

Compound 3, half-maximal inhibitory concentration: 100 nM
Beside the measured number, compound 3's estimate is 7.5-fold (0.88 log units) above it; measured number below the stated range.
By their numbers in this assay, from the lowest: compound 3; then compounds 2 and 1 (each within the scatter of the next).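

Substitution on the aromatic nitrogen of the five-membered aromatic ring with 3 nitrogen is not silent in this assay: (2,2-dimethyl-1,3-dioxolan-4-yl)methyl in place of 4-hydroxy-5-(hydroxymethyl)oxolan-2-yl gives an 8.2-fold lower number from compound 1 to compound 3 (0.91 log units; beyond the scatter), the first readable step in the series. The two groups have the same count of 8 heavy atoms, yet they differ in other ways: the leaving group has 2 hydrogen-bond donors and 3 defined stereocentres, while the entering group has 0 hydrogen-bond donors and 1 defined stereocentre, and its five-membered non-aromatic ring has 2 hetero atoms rather than 1. Nothing available ties the step to any one of these differences.

On these data alone, whether the lower number goes with the ring of the entering group or with the absence of hydroxy groups remains open, and a simple open-chain diol or a plain alkyl chain on the same nitrogen would help separate the two. Also open, as far as these compounds go, is how an amine or a carboxylic acid at this position would read in this assay, and whether the mirror-image form of the entering group would give the same number.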